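A few compounds are considered here, and "the series" means these few. Any claim that something is new, unique, unknown or untested is made for them only; others in the source may bear on it.

Series notes. The shared core of compound 1 `O=C(COc1ccc2cc(/C=C3/SC(=O)NC3=O)ccc2c1)Nc1ccccn1` is kept throughout; only the aryl group on the amide-type nitrogen varies. In an assay on isolated protein for inhibition of histone deacetylase 4 (Homo sapiens), with a stated time of 1 h (on this read-out higher numbers stand for weaker inhibition and lower numbers for stronger inhibition), compound 1 gives 17000 nM. Compound 2 `O=C(COc1ccc2cc(/C=C3/SC(=O)NC3=O)ccc2c1)Nc1cccc(F)n1` gives 840 nM in this assay, a change of a 20-fold lower number from compound 1 to compound 2 (1.31 log units; beyond the scatter). Compound 3 `O=C(COc1ccc2cc(/C=C3/SC(=O)NC3=O)ccc2c1)Nc1c(F)cc(F)cc1Br` gives 1100 nM in this assay; the step of a 15-fold lower number from compound 1 to compound 3 (1.19 log units; beyond the scatter) is large, whereas a 1.3-fold higher number from compound 2 to compound 3 (0.12 log units; within the scatter) stays within the scatter. Compound 3 thus stands second highest of the three numbers, close to compound 2 and far from compound 1.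

Compound 4 `O=C(COc1ccc2cc(/C=C3/SC(=O)NC3=O)ccc2c1)Nc1cccc(Cl)c1` differs from compound 3 by 3-chlorophenyl in place of 2-bromo-4,6-difluorophenyl on an amide-type nitrogen. The precedents that bear on this are the two replacements of the aryl group on the amide-type nitrogen: a 15-fold lower number from compound 1 to compound 3 (1.19 log units; beyond the scatter) and a 1.3-fold higher number from compound 2 to compound 3 (0.12 log units; within the scatter). The two halogen-bearing aryl groups sit close together in number; only the unsubstituted pyridin-2-yl of compound 1 stands far higher. The 3-chlorophenyl group keeps a halogen on the ring but carries fewer halogens than compound 3, so a moderate rise toward the number of compound 1 is expected, with wide uncertainty. Compound 4 is expected at 2500 nM, ranging from 600 nM to 10000 nM. The estimate means a step of a 2.3-fold higher number from compound 3 to compound 4 (0.36 log units; beyond the scatter).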

Compound 4, half-maximal inhibitory concentration: 3800 nM
Compound 4: middle estimate off by 1.5-fold (0.18 log units), on the low side; the range from low to high includes it.
By their numbers in this assay, from the lowest: compounds 2 and 3 (each within the scatter of the next); then compound 4; then compound 1.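

In this assay, the 3-chlorophenyl group keeps part of the gain over pyridin-2-yl, with a 4.5-fold lower number from compound 1 to compound 4 (0.65 log units; beyond the scatter), but it does not reach the level of the other two halogen-bearing aryl groups, with a 3.5-fold higher number from compound 3 to compound 4 (0.54 log units; beyond the scatter) and a 4.5-fold higher number from compound 2 to compound 4 (0.66 log units; beyond the scatter). Halogen on the aryl group therefore does not by itself fix the number, and compound 3 and compound 4 show that a ring of carbon only does not either. No data at hand explain these differences.

Compound 3 and compound 4 differ in the kind, count and placement of halogen at once, so these three remain unseparated. Also open, going by these compounds, is how the number would respond to unsubstituted phenyl, 3-fluorophenyl, 3-aminophenyl or 3-carboxyphenyl on the same amide-type nitrogen.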